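Hindlimb series: para dimethylamino analogue of compound 2

A few compounds are considered here, and "the series" means these few. Any claim that something is new, unique, unknown or untested is made for them only; others in the source may bear on it.

Compound 1 `Cc1cccc(C(=O)NN2C(=O)NC3(CC3(C)C)C2=O)c1` gives 100 mg/kg in a functional assay on the whole organism (Hindlimb) for inhibition, with Mus musculus as the target, with a stated time of 0.5 h (on this read-out lower numbers stand for an effect already at smaller amounts and higher numbers for an effect only at larger amounts of compound), and compound 2 `CC1(C)CC12NC(=O)N(NC(=O)c1ccc(Cl)cc1)C2=O` gives 100 mg/kg; the step of no change at the digits printed from compound 1 to compound 2 (within the scatter) lies within the scatter. Compound 3 `COc1ccc(C(=O)NN2C(=O)NC3(CC3(C)C)C2=O)cc1OC` gives 300 mg/kg, a number beyond the scatter above both. Compound 2 thus shares the lowest number of the three with compound 1. Compound 4 `CN(C)c1ccc(C(=O)NN2C(=O)NC3(CC3(C)C)C2=O)cc1` differs from compound 2 by dimethylamino in place of chloro on an aromatic carbon. Going by the values given here, no measured step changes a para substituent alone; the only aryl step, no change at the digits printed from compound 1 to compound 2 (within the scatter), was flat, while compound 3 shows that dimethoxy substitution raises the number. The step of a 2.0-fold higher number from compound 2 to compound 4 (0.30 log units; within the scatter) is therefore expected to be small, a slight rise at most. Compound 4 is estimated at 200 mg/kg, in the range 100 mg/kg to 500 mg/kg.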

Compound 4, minimum effective dose: 300 mg/kg
Beside the measured number, compound 4's estimate is 1.5-fold (0.18 log units) below it; the measured number falls inside the stated range.
By their numbers in this assay, from the lowest: compounds 1 and 2 (each within the scatter of the next); then compounds 3 and 4 (each within the scatter of the next).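

At this position, on an aromatic carbon para to a large group, dimethylamino in place of chloro gives a 3.0-fold higher number from compound 2 to compound 4 (0.48 log units; beyond the scatter) in this assay, a modest step. The earlier aryl step, no change at the digits printed from compound 1 to compound 2 (within the scatter), was flat, so a single substituent change on the aromatic ring can move this read-out after all. No supporting data bear on why the number rises.

Open, from the compounds shown here alone, is whether a primary amine or a carboxylic acid at this position stays level with compound 2 or rises to the number of compound 4.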